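A few compounds are considered here, and "the series" means these few. Any claim that something is new, unique, unknown or untested is made for them only; others in the source may bear on it.

Compound 1 has the structure `COc1cc2c(Oc3ccc(NC(=O)c4nn(-c5ccccc5C(F)(F)F)c(=O)cc4C)cc3F)ccnc2cc1OCCCN1CCC(C)CC1`. In a functional assay on NCI-H460 cells (Homo sapiens) for inhibition, read by MTT assay, with a stated time of 72 h (a lower number here means a stronger inhibitor, a higher number a weaker inhibitor), compound 1 gives 200 nM. Compound 2, with the structure `COc1cc2c(Oc3ccc(NC(=O)c4nn(-c5ccccc5C(F)(F)F)c(=O)cc4C)cc3F)ccnc2cc1OCCCN1CCN(C)CC1`, carries 4-methylpiperazin-1-yl in place of 4-methylpiperidin-1-yl on a saturated chain carbon, three bonds along the chain from an oxygen on an aromatic ring. In this assay compound 2 gives 240 nM, and the step is a 1.2-fold higher number from compound 1 to compound 2 (0.08 log units; within the scatter).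

Compound 3, with the structure `COc1cc2c(Oc3ccc(NC(=O)c4nn(-c5ccccc5OC(F)(F)F)c(=O)cc4C)cc3F)ccnc2cc1OCCCN1CCC(C)CC1`, shares the side chain of compound 1 but differs in its core by trifluoromethoxy in place of trifluoromethyl on an aromatic carbon. In this assay compound 3 gives 290 nM, and the step is a 1.5-fold higher number from compound 1 to compound 3 (0.16 log units; within the scatter). The three values therefore sit close together, none of them separated from another beyond the scatter.

Compound 4, with the structure `COc1cc2c(Oc3ccc(NC(=O)c4nn(-c5ccccc5OC(F)(F)F)c(=O)cc4C)cc3F)ccnc2cc1OCCCN1CCN(C)CC1`, has not yet been measured in this assay. Within the data shown here, it differs from compound 3 by 4-methylpiperazin-1-yl in place of 4-methylpiperidin-1-yl on a saturated chain carbon, three bonds along the chain from an oxygen on an aromatic ring, which is the same change, at the same place, as the one that separates compound 1 from compound 2; among the four compounds it occurs twice. Among the measured compounds shown here, the one measured instance of this change, from compound 1 to compound 2, stayed within the scatter, and compound 4 shares the trifluoromethoxy core with compound 3 rather than the trifluoromethyl core of compounds 1 and 2.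

Compound 4 is expected to show a step of a 1.2-fold higher number from compound 3 to compound 4 (0.08 log units; within the scatter). This expectation rests on the measured step of a 1.2-fold higher number from compound 1 to compound 2 (0.08 log units; within the scatter). In this assay compound 4 is estimated at 350 nM, with a likely range from 170 nM to 720 nM.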

Compound 4, half-maximal inhibitory concentration: 260 nM
Beside the measured number, compound 4's estimate is 1.3-fold (0.13 log units) above it; low and high end bracket the measured number.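

In this assay, the change to 4-methylpiperazin-1-yl on the trifluoromethoxy core gives a 1.1-fold lower number from compound 3 to compound 4 (0.05 log units; within the scatter), and this step agrees with the one seen on the trifluoromethyl core: the same change on two cores in this assay, a 1.2-fold higher number (0.08 log units; within the scatter) from compound 1 to compound 2 and a 1.1-fold lower number (0.05 log units; within the scatter) from compound 3 to compound 4, 1.3-fold (0.13 log units) apart, within the scatter of two such steps. The exchange of trifluoromethyl for trifluoromethoxy, read with the 4-methylpiperazin-1-yl side chain in place, gives a 1.1-fold higher number from compound 2 to compound 4 (0.03 log units; within the scatter), and it too agrees with its earlier counterpart: the same change on two cores in this assay, a 1.5-fold higher number (0.16 log units; within the scatter) from compound 1 to compound 3 and a 1.1-fold higher number (0.03 log units; within the scatter) from compound 2 to compound 4, 1.3-fold (0.13 log units) apart, within the scatter of two such steps. Among these compounds, each change therefore carries from one core to the other as a step within the scatter, but since all four steps are this small, the set does not show whether a change with a clear effect would carry over in the same way, and it rests on only two partners for each change in one cell assay.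

The compounds shown leave open whether a morpholin-4-yl or a dimethylamino group at the end of the chain, or a chain shorter or longer than the propyl chain, would still keep the values this close together. They also leave open what a chlorine or a nitrile on that aromatic carbon, in place of trifluoromethyl or trifluoromethoxy, would do in this assay.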